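The source may hold more compounds than are shown below. What is called first, only, known or untested is meant among the compounds shown, and "the series" means these compounds.

Compound 3 `CN1CCC(NC(=O)c2ccncc2Nc2cc(-c3ccc4ccn(C)c4c3)c3nccnc3c2)CC1` gives > 1 h in an ADME assay on microsomes from liver (Mus musculus, strain CD-1) for metabolic stability, read by LC-MS, tested at 2 uM; on this read-out lower numbers stand for a shorter-lived compound and higher numbers for a longer-lived compound. That entry is a limit of the assay and not a number.

Two sulfonamide compounds give measured values: compound 1 `CN1CCC(CNS(=O)(=O)c2ccccc2Nc2cc(-c3ccc4ccn(C)c4c3)c3nccnc3c2)C1` gives 0.633 h, and compound 2 `Cn1ccc2ccc(-c3cc(Nc4ccccc4S(=O)(=O)NCC4CCOCC4)cc4nccnc34)cc21` gives 0.3 h.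

Compound 4 `Cn1ccc2ccc(-c3cc(Nc4cnccc4C(=O)NCC4COCCN4)cc4nccnc34)cc21` differs from compound 3 as follows: (morpholin-3-yl)methyl in place of 1-methylpiperidin-4-yl on an amide-type nitrogen. In words, (morpholin-3-yl)methyl stands in place of 1-methylpiperidin-4-yl on an amide-type nitrogen.

For the measured compounds named here, only one measured step bears on this change: a 2.1-fold lower number from compound 1 to compound 2 (0.32 log units; beyond the scatter), a modest step beyond the scatter. There, oxan-4-yl replaces 1-methylpyrrolidin-3-yl on a saturated chain carbon bound to a sulfonamide nitrogen. The parallel is loose, since the groups and their place both differ, and one step sets no pattern.

On the strength of that step, a modest move to a lower number is expected in this assay. The estimated step is an at least 1.6-fold lower number from compound 3 to compound 4 (0.22 log units; that floor lies within the scatter), and it is only approximate given the limit at its start. For compound 4 the estimated value is 0.6 h, with an expected range of 0.25 h to 1.3 h.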

Compound 4, half-life: > 1 h
Compound 4: no number, only a limit; the forecaster's own chance of this, stated with the estimate: 25%; middle value at least 1.6-fold (0.22 log units) away from the limit.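

Compound 3 and compound 4 each carry only a limit in this assay, not a number, so no step between them can be read: the limit of > 1 h in this assay, at which 2 of the 4 values shown sit.

Still open, as far as these compounds go, is whether (morpholin-3-yl)methyl in place of 1-methylpiperidin-4-yl on an amide-type nitrogen changes the half-life at all.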